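A few compounds are considered here, and "the series" means these few. Any claim that something is new, unique, unknown or untested is made for them only; others in the source may bear on it.

The measured compounds so far:

Compound 1, `N=C(NCc1ccccc1)[C@@H]1CCC(=O)N1Cc1ccc([N+](=O)[O-])cc1`, gives 24% in a functional assay on SH-SY5Y cells (Homo sapiens) for cytotoxicity, read by MTT assay, with stated times of 8 h, 30 min and 12 h, tested at 0.5 uM; a lower number here means a weaker effect, a higher number a stronger effect of the compound at the concentration tested.
Compound 2, `N=C(NCc1ccc(O)cc1)[C@@H]1CCC(=O)N1Cc1ccc([N+](=O)[O-])cc1`, gives 31.3% in this assay.
Compound 3, `N=C(NCc1ccccc1)[C@@H]1CCC(=O)N1Cc1ccc(F)cc1`, gives 23.3% in this assay.

Compound 4, `N=C(NCc1ccc(O)cc1)[C@@H]1CCC(=O)N1Cc1ccc(F)cc1`, has not yet been measured in this assay. Compound 4 stands to compound 3 as compound 2 stands to compound 1: the difference is hydroxy in place of hydrogen on an aromatic carbon. The same change, made once before, gave a number 7.3 percentage points higher from compound 1 to compound 2 (within the scatter). The two cores on which this change is made differ by fluoro in place of nitro on an aromatic carbon, and that difference itself produced only a number 0.7 percentage points lower from compound 1 to compound 3 (within the scatter). The place of the entering hydroxy is described in the same words for both pairs, so the change is the same, not merely the same kind.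

Compound 3 shows the lowest of the three numbers, yet all three lie within the scatter of one another, so no order among them can be claimed. For compound 4 a step similar in size to the earlier one is expected, a number 6.7 percentage points higher from compound 3 to compound 4 (within the scatter), an expectation that rests on a number 7.3 percentage points higher from compound 1 to compound 2 (within the scatter) and on the near-identical cores shown by a number 0.7 percentage points lower from compound 1 to compound 3 (within the scatter). Compound 4 is therefore estimated at 30%, with a range from 19% to 42%.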

Compound 4, a percentage reported as activity, at one concentration (the size of the read-out at that concentration, not a potency): 42%
For compound 4 the middle estimate is 12 percentage points below the measured one; the range from low to high includes it.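

In this assay, hydroxy in place of hydrogen on the core of compound 3 gives a number 18.7 percentage points higher from compound 3 to compound 4 (beyond the scatter), and this step cannot be told apart from the one on the core of compound 1: the same change on two cores in this assay, a number 7.3 percentage points higher (within the scatter) from compound 1 to compound 2 and a number 18.7 percentage points higher (beyond the scatter) from compound 3 to compound 4, 11.4 percentage points apart, within the scatter of two such steps. Fluoro in place of nitro, carried onto the 4-hydroxybenzyl compounds, gives a number 10.7 percentage points higher from compound 2 to compound 4 (beyond the scatter), and again the two steps cannot be told apart: the same change on two cores in this assay, a number 0.7 percentage points lower (within the scatter) from compound 1 to compound 3 and a number 10.7 percentage points higher (beyond the scatter) from compound 2 to compound 4, 11.4 percentage points apart, within the scatter of two such steps. On these two cores, then, each change is compatible with a single step size, but this does not show that either change is larger on one core than on the other, and two cores tested at one concentration cannot show that the change carries to further cores in the series.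

As far as these compounds go, it remains open whether a methoxy group or an amine in the place of the hydroxy, or a chloro group or a nitrile in the place of the fluoro, would give similar numbers. Also open, from the compounds shown here alone, is how these four compounds compare at other concentrations.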